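The source may report more compounds than this note shows. Statements on the series, on what has been measured and on what is new or still open speak of the compounds shown alone.

Compound 1 `CC(=O)OC[C@H]1O[C@@H](n2cc(Cn3cc(/C=C4/C(=O)Nc5ccc(F)cc54)c4ccccc43)nn2)[C@H](OC(C)=O)[C@@H](OC(C)=O)[C@@H]1OC(C)=O` is the only one of the three measured compounds with a numbered result: in a functional assay on MCF7 cells (Homo sapiens) for cytotoxicity, read by sulforhodamine B assay, with a stated time of 48 h (on this read-out lower numbers stand for stronger inhibition and higher numbers for weaker inhibition), compound 1 gives 40400 nM. Compound 2 `CC(=O)OC[C@H]1O[C@@H](n2cc(CN3C(=O)/C(=C/c4ccc(C)cc4)c4ccccc43)nn2)[C@H](OC(C)=O)[C@@H](OC(C)=O)[C@@H]1OC(C)=O` in this assay reaches only a limit, > 100000 nM. Compound 3 `CC(=O)OC[C@H]1O[C@@H](n2cc(CN3C(=O)/C(=C\c4ccc(C)cc4)c4ccccc43)nn2)[C@H](OC(C)=O)[C@@H](OC(C)=O)[C@@H]1OC(C)=O` likewise gives only a limit in this assay, > 100000 nM. The step that the two limits leave unreadable from compound 2 to compound 3 cannot be sized because of the limit of > 100000 nM in this assay, at which 2 of the 3 values shown sit, even though the two structures are as close as possible, since (the fact that compounds 2 and 3 differ only in the configuration as drawn). So compound 2 stands at the weak end of what this assay can report, with no readable step leading away from it.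

Compound 4 `CC(=O)OC[C@H]1O[C@@H](n2cc(CN3C(=O)/C(=C/c4ccc(N(C)C)cc4)c4ccccc43)nn2)[C@H](OC(C)=O)[C@@H](OC(C)=O)[C@@H]1OC(C)=O` differs from compound 2 by dimethylamino in place of methyl on an aromatic carbon. Among the compounds with values here, none of the measured steps involves this kind of change, and the single measured step from compound 2 is unreadable, so no direction can be drawn from the data for this assay. The expected step is an at least 1.2-fold lower number from compound 2 to compound 4 (0.09 log units; that floor lies within the scatter), within scatter. Compound 4 is therefore estimated at about 80000 nM, with a range from 20000 nM to 250000 nM.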

Compound 4, half-maximal inhibitory concentration: 25200 nM
Estimate against measurement, compound 4: 3.2-fold (0.50 log units) above; measured number inside the range.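

In this assay, within the data shown here, the change from 4-methylphenyl to 4-(dimethylamino)phenyl gives the step of an at least 3.9-fold lower number from compound 2 to compound 4 (0.59 log units; beyond the scatter) and so provides the first readable comparison. Compounds 2 and 3 could not show this, as neither gave a readable step, whereas this result shows that changing the group on this aromatic carbon can move the number. From the compounds shown here alone, compound 2 has only a limit, > 100000 nM, and not a number, so the size of the step is a floor and its true size remains unknown.

The compounds shown do not tell whether another group on this carbon, such as methoxy, a primary amine or a carboxylic acid, would give a lower or a higher number. They also leave open whether dimethylamino would have a similar effect on compound 3, whose double bond is drawn Z.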